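Swapping a Pyrrolidine for an Oxetane on the Sulfonyl Group

The source may hold more compounds than are shown below. What is called first, only, known or untested is meant among the compounds shown, and "the series" means these compounds.

Compound 1 `O=C(Nc1cccc(S(=O)(=O)N2CCCC2)c1)c1cccnc1N1CCC2(CC1)CC2` — 4420 nM
Compound 2 `CC(C)(CO)S(=O)(=O)c1cccc(NC(=O)c2cccnc2N2CCC3(CC2)CC3)c1` — 31300 nM
Compound 3 `O=C(Nc1cccc(S(=O)(=O)C2CCCC2)c1)c1cccnc1N1CCCCC1` — 5030 nM

These values come from a functional assay on OVCAR-3 cells (Homo sapiens) for antiproliferative activity; a higher number here means that more compound is needed for the effect, a lower number that less compound is needed. Compound 1 holds the lowest number of the three: compound 3 sits within the scatter of it, while compound 2 lies well beyond. Compound 4 `O=C(Nc1cccc(S(=O)(=O)C2COC2)c1)c1cccnc1N1CCC2(CC1)CC2` differs from compound 1 in one place: oxetan-3-yl in place of pyrrolidin-1-yl on a sulfonyl sulfur. Among the compounds with values here, the only measured step at this position is a 7.1-fold higher number from compound 1 to compound 2 (0.85 log units; beyond the scatter), where an open-chain group bearing a hydroxyl replaced the pyrrolidin-1-yl. Compound 3, which carries a carbon-linked ring on the sulfonyl sulfur but a different core, shows a number close to compound 1. An oxetan-3-yl is also a carbon-linked small ring, yet one with a hetero atom, so a modest rise is expected, a 2.3-fold higher number from compound 1 to compound 4 (0.35 log units; beyond the scatter). Compound 4 is therefore estimated at 10000 nM, between 3500 nM and 30000 nM.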

Compound 4, half-maximal effective concentration: 12600 nM
Compound 4: middle estimate off by 1.3-fold (0.10 log units), on the low side; low and high end bracket the measured number.
By their numbers in this assay, from the lowest: compounds 1 and 3 (each within the scatter of the next); then compound 4; then compound 2.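

With the core of compound 1 held fixed, the three groups on the sulfonyl sulfur now fall into an order: there is a 2.9-fold higher number from compound 1 to compound 4 (0.45 log units; beyond the scatter), and a 2.5-fold lower number from compound 2 to compound 4 (0.40 log units; beyond the scatter). Both carbon-linked groups, in compound 2 and compound 4, thus give higher numbers than the pyrrolidin-1-yl of compound 1. Nothing shown here explains this order. Still open, on these data alone, is whether another nitrogen-linked ring on the sulfonyl sulfur, such as morpholin-4-yl, would keep the number close to that of compound 1.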